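The source may hold more compounds than are shown below. What is called first, only, known or untested is meant among the compounds shown, and "the series" means these compounds.

Measured compounds:
- compound 1, `COc1ccc(NS(=O)(=O)/C=C/c2c(F)c(F)c(F)c(F)c2F)cc1N`, with 75000 nM
- compound 2, `COc1cc(OC)c(/C=C/S(=O)(=O)Nc2ccc(OC)c(F)c2)c(OC)c1`, with 200 nM

Both compounds were tested in a functional assay on DU-145 cells (Homo sapiens) for cytotoxicity, read by trypan blue exclusion, with a stated time of 96 h; a lower number here means a stronger inhibitor, a higher number a weaker inhibitor. In this assay compound 1 gives 75000 nM, while compound 2 gives 200 nM. Compound 2 thus stands at the lowest of the two numbers, and the gap to compound 1 lies well beyond the scatter of the method; since the two structures differ in more than one place, nothing more can be drawn from that pair than what the two values show.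

The next compound, compound 3, `COc1cc(OC)c(/C=C/S(=O)(=O)Nc2ccc(OC)c(NC(C)(C)C(=O)O)c2)c(OC)c1`, is not yet measured. It differs from compound 2 in a single place: (1-carboxy-1-methylethyl)amino in place of fluoro on an aromatic carbon. Going by the values given here, no step between measured compounds covers this kind of change, so the expectation rests on compound 2 alone. The account expects a small step toward a higher number, at the edge of the scatter, given as a 2.0-fold higher number from compound 2 to compound 3 (0.30 log units; within the scatter). For compound 3 the estimated value in this assay is 400 nM, with a range from 100 nM to 2000 nM.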

Compound 3, half-maximal inhibitory concentration: 70 nM
Compound 3: the middle estimate sits 5.7-fold (0.76 log units) above what was measured, outside the stated range (below it).
By their numbers in this assay, from the lowest: compound 3; then compound 2; then compound 1.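

Going by these compounds alone, the aromatic carbon ortho to a methoxy group and meta to a large group, which until now had been seen only with fluoro on this core, also accepts a far larger substituent. In this assay, putting (1-carboxy-1-methylethyl)amino in place of fluoro gives a 2.9-fold lower number from compound 2 to compound 3 (0.46 log units; beyond the scatter), so 7 heavy atoms, 2 hydrogen-bond donors and 2 hydrogen-bond acceptors enter at this carbon with no loss in this read-out, and the number in fact falls. The data give the direction and size of this step but nothing measured accounts for it.

The compounds shown leave open which part of the entering group carries the step: the amino nitrogen, the two methyl groups or the carboxylic acid. As far as these compounds go, a plain amine on this carbon, a methyl ester in place of the carboxylic acid, or a chain without the two methyl groups would each bear on that question, and it also remains open whether the same exchange would hold on a core other than that of compound 2.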